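This account rests on a few compounds, and the source may have more. Where it says the series, first, only, none or still open, it means among the compounds named here.

Measured in a functional assay on MCF7 cells (Homo sapiens) for inhibition, read by resazurin assay, with a stated time of 72 h; on this read-out higher numbers stand for weaker inhibition and lower numbers for stronger inhibition:
compound 1, `COc1cc(N2C(=O)C(Oc3ccccc3)C2c2ccc(SC)cc2)cc(OC)c1OC`, gives 152 nM;
compound 2, `CCOc1ccc(C2C(O)C(=O)N2c2cc(OC)c(OC)c(OC)c2)cc1`, gives 7 nM;
compound 3, `CCOc1ccc(C2C(Oc3ccccc3)C(=O)N2c2cc(OC)c(OC)c(OC)c2)cc1`, gives 69 nM.

Compound 4, `COc1cc(N2C(=O)C(O)C2c2ccc(SC)cc2)cc(OC)c1OC`, has not yet been measured. It differs from compound 2 in one place: methylsulfanyl in place of ethoxy on an aromatic carbon. The same change has been measured once already, from compound 3 to compound 1: methylsulfanyl in place of ethoxy on an aromatic carbon, and there it gave a 2.2-fold higher number from compound 3 to compound 1 (0.34 log units; beyond the scatter). The two cores on which this change is made differ as follows: hydrogen in place of phenyl on an oxygen on a saturated carbon, and that difference by itself gave a 9.9-fold higher number from compound 2 to compound 3 (0.99 log units; beyond the scatter). The place of the change is described in the same words for both pairs, so it is the same change carried onto a second core. Among the compounds with values here, for compound 4 a step of similar size is expected, a 2.1-fold higher number from compound 2 to compound 4 (0.33 log units; beyond the scatter), because the one measured example of this change gave a 2.2-fold higher number from compound 3 to compound 1 (0.34 log units; beyond the scatter). Compound 4 is therefore estimated at 15 nM, with a likely range from 6 nM to 40 nM.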

Compound 4, half-maximal inhibitory concentration: 5 nM
Compound 4: middle estimate off by 3.0-fold (0.48 log units), on the high side; the whole stated range lies above it.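

In this assay, with hydrogen on the oxygen, methylsulfanyl in place of ethoxy gives a 1.4-fold lower number from compound 2 to compound 4 (0.15 log units; within the scatter), so the step seen with phenyl on that oxygen did not carry over unchanged to this core: the same change on two cores in this assay, a 2.2-fold higher number (0.34 log units; beyond the scatter) from compound 3 to compound 1 and a 1.4-fold lower number (0.15 log units; within the scatter) from compound 2 to compound 4, 3.1-fold (0.49 log units) apart, beyond the scatter of two such steps

Hydrogen in place of phenyl gives a 30-fold lower number from compound 1 to compound 4 (1.48 log units; beyond the scatter), so this change lowers the number on both cores, though not by the same amount: the same change on two cores in this assay, a 9.9-fold higher number (0.99 log units; beyond the scatter) from compound 2 to compound 3 and a 30-fold higher number (1.48 log units; beyond the scatter) from compound 4 to compound 1, 3.1-fold (0.49 log units) apart, beyond the scatter of two such steps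

These two pairs show that the effect of one change depends on the other in these compounds, but they do not show why, or whether this would hold for other groups.

The compounds shown leave open what a methyl group or a longer chain on that oxygen would do. They also leave open how an amine in place of the ethoxy or methylsulfanyl group would behave on either core.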